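Removing the Aryl Methyl from a Selenocyanate Carbamate

This account rests on a few compounds, and the source may have more. Where it says the series, first, only, none or still open, it means among the compounds named here.

Three selenocyanate carbamates have been measured in an ADME assay on BEAS-2B cells (Homo sapiens) for cytotoxicity, read by MTT assay, with a stated time of 72 h; on this read-out lower numbers stand for stronger inhibition of growth and higher numbers for weaker inhibition of growth. Compound 1 `CCCCCCOC(=O)Nc1ccc([Se]C#N)cc1` gives 2800 nM, compound 2 `N#C[Se]c1ccc(NC(=O)Oc2ccc(F)cc2)cc1` gives 19800 nM, and compound 3 `Cc1ccc(OC(=O)Nc2ccc([Se]C#N)cc2)cc1` gives 5600 nM. Compound 3 thus stands second highest of the three: its value and that of compound 1 lie within the scatter, while the step of a 3.5-fold lower number from compound 2 to compound 3 (0.55 log units; beyond the scatter) lies beyond it. Compound 4 `N#C[Se]c1ccc(NC(=O)Oc2ccccc2)cc1` differs from compound 3 by hydrogen in place of methyl on an aromatic carbon. Among the compounds with values here, only the step from compound 2 to compound 3 touches the same position, and it was modest, so the bearing on removing the methyl is uncertain. Compound 4 is therefore expected to show a step of a 1.3-fold higher number from compound 3 to compound 4 (0.10 log units; within the scatter), most likely within the scatter. The estimate for compound 4 is 7000 nM, ranging from 3000 nM to 17000 nM.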

Compound 4, concentration for 50% growth inhibition: 8900 nM
Estimate against measurement, compound 4: 1.3-fold (0.10 log units) below; the measured number falls inside the stated range.
By their numbers in this assay, from the lowest: compounds 1, 3 and 4 (each within the scatter of the next, the first and the last beyond it); then compound 2.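

In this assay, hydrogen and methyl at this position, para to a large group, are not told apart (a 1.6-fold higher number from compound 3 to compound 4 (0.20 log units; within the scatter)). Fluoro at the same place does stand apart from hydrogen (a 2.2-fold lower number from compound 2 to compound 4 (0.35 log units; beyond the scatter)), so among these three compounds only fluoro separates from the others. Phenyl in place of hexyl on the oxygen next to a carbonyl group also gives a step beyond the scatter (a 3.2-fold higher number from compound 1 to compound 4 (0.50 log units; beyond the scatter)). As far as these compounds go, whether a chloro or methoxy group here would group with hydrogen and methyl or with fluoro remains open, as does the effect of a butyl chain on that oxygen. No evidence available here explains these steps.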